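This account rests on a few compounds, and the source may have more. Where it says the series, first, only, none or still open, it means among the compounds named here.

Measured compounds:
compound 1 `COc1cc(/C=C/C(=O)c2cccc(-n3cc(-c4ccccc4)[nH]c3=O)c2)ccc1O` gives 2780 nM
compound 2 `COc1cc(/C=C/C(=O)c2cccc(-n3cc(-c4ccccc4)[nH]c3=O)c2)cc(OC)c1OC` gives 1930 nM

The two measured compounds come from the same series. In a functional assay on BT-549 cells (Homo sapiens) for inhibition (on this read-out lower numbers stand for stronger inhibition of growth and higher numbers for weaker inhibition of growth), compound 1 gives 2780 nM, and compound 2 gives 1930 nM; the two numbers lie within the usual scatter of each other, so compound 1 stands on a par with compound 2 on this read-out and nothing can be said of an order between them.

Compound 3 `COc1cc(/C=C/C(=O)c2cccc(-n3cc(-c4ccc(Cl)cc4)[nH]c3=O)c2)ccc1O` is the next member. It differs from compound 1 in one place: chloro in place of hydrogen on an aromatic carbon, a chloro in place of hydrogen on an aromatic carbon. Among the measured compounds shown here, no measured pair in this set shows the effect of such an exchange, so there is no step to lean on. Given that the one comparison available, between compound 1 and compound 2, stays within the scatter, the change to compound 3 is expected to produce no step beyond the scatter in this assay, with the step of a 1.1-fold lower number from compound 1 to compound 3 (0.05 log units; within the scatter) estimated as small and of uncertain direction. Compound 3 is therefore expected to give about 2500 nM, with a range from 1000 nM to 6000 nM.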

Compound 3, concentration for 50% growth inhibition: 2520 nM
For compound 3 the middle estimate is 1.0-fold (0.00 log units) below the measured one; measured number inside the range.
By their numbers in this assay, from the lowest: compounds 2, 3 and 1 (each within the scatter of the next).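

Among the compounds shown here, exchanging phenyl for 4-chlorophenyl provides the first single-place comparison: in this assay, the step is a 1.1-fold lower number from compound 1 to compound 3 (0.04 log units; within the scatter). For the compounds shown here, at this place, on an aromatic carbon of a six-membered aromatic ring of carbon only and para to a large group, the added chloro, a single heavy atom with no ring and no net charge, therefore produces no step that can be told from the scatter, so this position accepts a chloro without a readable gain or loss in growth inhibition. No measurement of any property of these compounds bears on this result.

The compounds shown leave open whether this position stays as flat with a group other than chloro, such as a methoxy group, a carboxylic acid, an amine or a longer alkyl chain, since a single exchange within the scatter cannot show how the read-out would respond to a different substituent. They also leave open whether a chloro elsewhere on this ring would give a step beyond the scatter, and so whether the result is particular to this position or holds for the ring as a whole.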